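Sulfonyl Aryl Swap on a Nicotinohydrazide Core

A few compounds are considered here, and "the series" means these few. Any claim that something is new, unique, unknown or untested is made for them only; others in the source may bear on it.

Measured compounds:
- compound 1, `CC(=O)Nc1ccc(S(=O)(=O)NNC(=O)c2cccnc2Nc2ccc(Cl)cc2)cc1` — < 100000 nM in a functional assay on HOP-62 cells (Homo sapiens) for antiproliferative activity; on this read-out higher numbers stand for weaker inhibition of growth and lower numbers for stronger inhibition of growth
- compound 2, `O=C(NNS(=O)(=O)c1ccc(F)cc1)c1cccnc1Nc1ccc(Cl)cc1Cl` — 30900 nM in this assay

Compound 1 sits at a limit rather than a number: its value of < 100000 nM in this assay is the boundary of what the test reports, as noted by the limit of < 100000 nM in this assay, at which 1 of the 2 values shown sits. Compound 2 reaches 30900 nM in this assay. Going by the values given here, compound 2 differs from compound 1 in more than one place, so no single step connects the two and their values show only that each compound is a weak inhibitor of growth on these cells.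

Compound 3, `O=C(NNS(=O)(=O)c1ccc(Cl)cc1Cl)c1cccnc1Nc1ccc(Cl)cc1`, is compound 1 with one change: 2,4-dichlorophenyl in place of 4-acetamidophenyl on a sulfonyl sulfur. No change of this kind has been measured here. The expected step from compound 1 to compound 3 rests on weak ground. Since compound 1 shows only a limit, any shift toward stronger inhibition is expected to be modest, and a step that the limit leaves unreadable from compound 1 to compound 3 is estimated. On that basis compound 3 is expected to give 35000 nM in this assay, within a range from 8000 nM to 100000 nM.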

Compound 3, concentration for 50% growth inhibition: 16600 nM
For compound 3 the middle estimate is 2.1-fold (0.32 log units) above the measured one; the range from low to high includes it.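

No size can be given for the step from compound 1 to compound 3, because compound 1 has only a limit and not a number: the limit of < 100000 nM in this assay, at which 1 of the 3 values shown sits.

The compounds shown leave open how much 2,4-dichlorophenyl in place of 4-acetamidophenyl on a sulfonyl sulfur changes growth inhibition in this assay, or whether it changes it at all.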